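The source may hold more compounds than are shown below. What is called first, only, known or untested is meant among the compounds shown, and "the series" means these compounds.

Measured so far in a physicochemical assay for pharmacokinetics, at pH 6; on this read-out lower numbers stand for a shorter-lived compound and higher numbers for a longer-lived compound:
- compound 1 `O=C(O)CCn1c(=O)oc2cc(Cl)c(Cl)cc21`: 334 h
- compound 2 `Cc1ccc([C@@H](C)Oc2cc3onc(CCC(=O)O)c3cc2Cl)nn1`: > 1000 h (a limit, not a number)
- compound 3 `C[C@@H](Oc1cc2onc(CCC(=O)O)c2cc1Cl)c1ccc(Cl)cn1`: > 1000 h (a limit, not a number)

Within the data shown here, compound 1 at 334 h holds the only actual number. Compound 2 and compound 3 report limits only, as the limit of > 1000 h in this assay, at which 2 of the 3 values shown sit, records.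

Compound 4 `CCOc1cc2oc(=O)n(CCC(=O)O)c2cc1Cl` keeps the core of compound 1 and carries ethoxy in place of chloro on an aromatic carbon, ortho to a chloro group (ethoxy in place of chloro on an aromatic carbon).

Among the measured compounds shown here, no measured step covers this exchange. The only one available, a step that the two limits leave unreadable from compound 2 to compound 3, gives no size to carry over. The expectation therefore rests on compound 1 at 334 h, with no shift beyond the usual scatter expected and a wide margin left open. The expected change is a 1.5-fold higher number from compound 1 to compound 4 (0.18 log units; within the scatter). For compound 4 the estimated half-life in this assay is 500 h, with an expected range from 200 h to 1000 h.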

Compound 4, half-life: > 1000 h
Compound 4: a limit, no number; the forecaster's own chance of this, stated with the estimate: 20%; middle value at least 2.0-fold (0.30 log units) away from the limit.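

Among these compounds, on the shared core, ethoxy in place of chloro on an aromatic carbon, ortho to a chloro group, gives in this assay an at least 2.9-fold higher number from compound 1 to compound 4 (0.47 log units; beyond the scatter) and this is the only step with a readable size, the earlier step being unreadable. On these data alone, the value of compound 4 is a limit, not a number, so the size of this step is a lower bound and its full extent stays unknown. Compound 4 also moves to the ceiling of the read-out, so this position shifts the half-life enough to leave the measurable range: the limit of > 1000 h in this assay, at which 3 of the 4 values shown sit.

As far as these compounds go, whether methoxy or a longer chain such as propoxy on the same aromatic carbon would give a number inside the range of this assay stays open. The same holds for an amine at this position.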